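The source may report more compounds than this note shows. Statements on the series, on what has been measured and on what is new or still open speak of the compounds shown alone.

Three compounds have been measured in a functional assay on MGC-803 cells (Homo sapiens) for inhibition, read by MTT assay, with a stated time of 72 h; a higher number here means a weaker inhibitor, a lower number a stronger inhibitor:

compound 1 `CCc1cccc(NC(=O)CSc2nc(Nc3ccccc3)c3ccccc3n2)c1`: 15800 nM
compound 2 `C=CC(=O)Nc1cccc(NC(=O)CSc2nc(Nc3ccccc3)c3ccccc3n2)c1`: 7310 nM
compound 3 `O=C(CSc1nc(Nc2ccccc2)c2ccccc2n1)Nc1ccc(Cl)c(Cl)c1`: 37900 nM

Compound 2 stands lowest of the three in this assay; the nearest is compound 1, with a 2.2-fold lower number from compound 1 to compound 2 (0.33 log units; beyond the scatter), and the furthest is compound 3, with a 5.2-fold higher number from compound 2 to compound 3 (0.71 log units; beyond the scatter). Compound 1 and compound 3 are separated by a 2.4-fold higher number from compound 1 to compound 3 (0.38 log units; beyond the scatter).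

Compound 4 `C=CC(=O)Nc1cccc(NC(=O)CSc2nc(Nc3cccc(C)c3)c3ccccc3n2)c1` differs from compound 2 in one place: methyl in place of hydrogen on an aromatic carbon. Within the data shown here, every measured step so far changes the group on the amide-type nitrogen, and none touches the anilino group, so no measured step bears directly on this change. The three measured steps, all modest, show that single changes in this series move the number only by small amounts. Among the measured compounds shown here, with no direct precedent, the most defensible expectation is a step of no size beyond the scatter in this assay, in either direction. Compound 4 is therefore estimated at 7000 nM, within 3000 nM to 17000 nM. This corresponds to an expected 1.0-fold lower number from compound 2 to compound 4 (0.02 log units; within the scatter).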

Compound 4, half-maximal inhibitory concentration: 20900 nM
Beside the measured number, compound 4's estimate is 3.0-fold (0.48 log units) below it; measured number outside the range, above it.
By their numbers in this assay, from the lowest: compound 2; then compounds 1, 4 and 3 (each within the scatter of the next, the first and the last beyond it).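

In this assay, the anilino ring of the series proves responsive to change: going from anilino to (3-methylphenyl)amino gives a 2.9-fold higher number from compound 2 to compound 4 (0.46 log units; beyond the scatter). Among these compounds, this is the first measured step away from the group on the amide-type nitrogen, and it shows that adding a single carbon, as methyl on this aromatic carbon, weakens inhibition beyond the scatter, so this ring cannot be treated as a part of the molecule that tolerates substitution freely. No evidence is available to explain this shift.

As far as these compounds go, it remains open whether a chlorine, a methoxy group or an amine at this same ring carbon would give a step of similar size and direction, and whether a methyl on another carbon of that ring would do the same. From the compounds shown here alone, it is also open whether the same methyl would have a similar effect on compound 1, which carries an ethyl group in place of the vinylcarbonylamino group.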